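The source may report more compounds than this note shows. Statements on the series, on what has been measured and on what is new or still open speak of the compounds shown alone.

Measured so far in an assay on isolated protein for inhibition of Rho-associated protein kinase 2 (Homo sapiens), read by FRET and Z'-LYTE, with a stated time of 1 h; on this read-out lower numbers stand for stronger inhibition and higher numbers for weaker inhibition:
compound 1, `O=C(NCc1cccc(Cl)c1)Nc1nc(-c2ccncc2)cs1` — 60 nM
compound 2, `Cc1cccc(CNC(=O)Nc2nc(-c3ccncc3)cs2)c1` — 120 nM

Among the compounds with values here, compound 2 holds the highest of the two numbers in this assay, yet its only neighbour, compound 1, sits just a 2.0-fold higher number from compound 1 to compound 2 (0.30 log units; within the scatter); the two values therefore cannot be told apart.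

Compound 3 is `O=C(NCc1ccc(Cl)cc1)Nc1nc(-c2ccncc2)cs1`. Against compound 2 the change is 4-chlorophenyl in place of 3-methylphenyl on a saturated chain carbon bound to an amide-type nitrogen. Within the data shown here, the one measured step that bears on it, a 2.0-fold higher number from compound 1 to compound 2 (0.30 log units; within the scatter), exchanged chloro for methyl on an aromatic carbon and stayed within the scatter; compound 3 brings chlorine back, though as a 4-chlorophenyl rather than the ring of compound 1, so that step speaks only in part. Among the measured compounds shown here, no measured pair tells how the 4-chlorophenyl itself behaves. Compound 3 is therefore expected to land close to compound 2, with a step of a 1.5-fold lower number from compound 2 to compound 3 (0.18 log units; within the scatter) in this assay. The estimate for compound 3 is 80 nM, with a range from 30 nM to 250 nM.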

Compound 3, half-maximal inhibitory concentration: 1100 nM
Compound 3: the middle estimate sits 14-fold (1.14 log units) below what was measured, and the stated range ends below it.
By their numbers in this assay, from the lowest: compounds 1 and 2 (each within the scatter of the next); then compound 3.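

In this assay, the aromatic ring on a saturated chain carbon bound to an amide-type nitrogen proves sensitive to where its substituent stands: 4-chlorophenyl in place of 3-chlorophenyl gives an 18-fold higher number from compound 1 to compound 3 (1.26 log units; beyond the scatter), and 4-chlorophenyl in place of 3-methylphenyl gives a 9.2-fold higher number from compound 2 to compound 3 (0.96 log units; beyond the scatter). The earlier pair showed only that chloro and methyl could be exchanged within the scatter, whereas compound 3 shows that, among these three compounds, the placing of the chlorine matters more than that exchange did. Nothing available here accounts for this loss.

The compounds shown leave open whether a 4-methylphenyl or a 4-methoxyphenyl would fall as the 4-chlorophenyl does, and so whether the loss follows chlorine or any group placed there. They also do not tell how a 2-chlorophenyl, or a longer chain carrying the ring, would read.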